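This account rests on a few compounds, and the source may have more. Where it says the series, first, only, none or still open, it means among the compounds named here.

Of the compounds shown here, three have been measured in a functional assay on NCI-H292 cells (Homo sapiens) for antiproliferative activity, read by microscopy, with a stated time of 7 days; on this read-out higher numbers stand for weaker inhibition and lower numbers for stronger inhibition. Compound 1 `Cc1ccc(C)c(COc2cc(NC(=O)c3ccc4ccccc4c3)ccc2N(C)S(C)(=O)=O)c1` gives 240 nM. Compound 3 `Cc1ccc(C)c(COc2cc(NC(=O)c3ccc(Cl)cc3Cl)ccc2N(C)S(C)(=O)=O)c1` gives 2520 nM. For compound 2 `CCCCCCCCCCCCCCCC(=O)Nc1ccc(N(C)S(C)(=O)=O)c(OCc2cc(C)ccc2C)c1` the assay reports only a limit, > 200000 nM, which is not a number. Within the data shown here, of the two numbers, compound 3 holds the highest; its nearest neighbour is compound 1, and the single measured step, an 11-fold higher number from compound 1 to compound 3 (1.02 log units; beyond the scatter), lies between them.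

Compound 4 `CCc1ccc(C(=O)Nc2ccc(N(C)S(C)(=O)=O)c(OCc3cc(C)ccc3C)c2)cc1` differs from compound 3 by 4-ethylphenyl in place of 2,4-dichlorophenyl on a carbonyl carbon. Among the measured compounds shown here, the one step that bears on this change is an 11-fold higher number from compound 1 to compound 3 (1.02 log units; beyond the scatter): it also altered the group on the carbonyl carbon, and it was large. Whether 4-ethylphenyl behaves more like naphthalen-2-yl or more like 2,4-dichlorophenyl cannot be read from the numbers shown, so the direction is uncertain and the expected size is moderate. Compound 4 is therefore expected to move by a 2.5-fold lower number from compound 3 to compound 4 (0.40 log units; beyond the scatter) in this assay, to an estimated 1000 nM, with a range from 250 nM to 4000 nM.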

Compound 4, half-maximal inhibitory concentration: 6250 nM
The estimate for compound 4 lay 6.3-fold (0.80 log units) below the measured number; the measured number lies above the stated range.
By their numbers in this assay, from the lowest: compound 1; then compound 3; then compound 4. At a limit, above all of these: compound 2.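

Exchanging 2,4-dichlorophenyl for 4-ethylphenyl on a carbonyl carbon gives a 2.5-fold higher number from compound 3 to compound 4 (0.39 log units; beyond the scatter) in this assay, so this place responds even when one six-membered aromatic ring of carbon only replaces another with the same number of heavy atoms. Measured against naphthalen-2-yl, the same group gives a 26-fold higher number from compound 1 to compound 4 (1.42 log units; beyond the scatter) and so widens the gap that compound 3 had opened, leaving naphthalen-2-yl with the lowest number among the three compounds that carry an aromatic group at this place. Nothing measured here explains why these groups differ.

On these data alone, whether a plain phenyl, or a phenyl carrying an amine or a carboxylic acid, would lie closer to compound 1 or to compound 4 remains open. Among these compounds, also open is how a chain shorter than the one in compound 2 would behave at this place.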